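Shortening an Amide Chain and Expected Cytotoxicity

The source may report more compounds than this note shows. Statements on the series, on what has been measured and on what is new or still open speak of the compounds shown alone.

Compound 1, `COC(=O)CC(=O)NC1=CS(=O)(=O)O[C@@]12[C@@H](CO[Si](C)(C)C(C)(C)C)O[C@@H](n1cc(C)c(=O)n(C)c1=O)[C@@H]2O[Si](C)(C)C(C)(C)C`: 400000 nM
Compound 2, `Cc1cn([C@@H]2O[C@@H]3COC(=O)[C@]3(OS(C)(=O)=O)[C@H]2O)c(=O)[nH]c1=O`: >= 400000 nM

Within the data shown here, in a functional assay on HEL cells (Homo sapiens) for cytotoxicity, read by microscopy (on this read-out lower numbers stand for higher toxicity in this test and higher numbers for lower toxicity in this test), compound 1 gives 400000 nM, the only plain number in this small set. Compound 2 reaches only a limit of the assay, >= 400000 nM, so its value is a limit and not a number. Compound 1 therefore stands at the single measured point, with the other compound sitting at the limit (the limit of >= 400000 nM in this assay, at which 1 of the 2 values shown sits).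

Compound 3, `CC(=O)NC1=CS(=O)(=O)O[C@@]12[C@@H](CO[Si](C)(C)C(C)(C)C)O[C@@H](n1cc(C)c(=O)n(C)c1=O)[C@@H]2O[Si](C)(C)C(C)(C)C`, differs from compound 1 by hydrogen in place of methoxycarbonyl on a saturated chain carbon bound to a carbonyl carbon. Among the measured compounds shown here, no measured pair with a single change is available, so the step is judged from the structural change alone, and it is expected to move this assay little, if at all, beyond the scatter. Compound 3 is expected to give 400000 nM, between 200000 nM and 800000 nM, a step of no change at the digits printed from compound 1 to compound 3 (within the scatter) that is expected to stay within the scatter. Given the limit (the limit of >= 400000 nM in this assay, at which 1 of the 2 values shown sits), a limit rather than a number for compound 3 is also quite possible.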

Compound 3, minimum cytotoxic concentration: >= 80000 nM
Compound 3: no number, only a limit (the forecaster's own chance of this, stated with the estimate: 60%); the middle value does not contradict the limit.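

Compound 3 gives only a limit in this assay, >= 80000 nM, and not a number. The step from compound 1 to compound 3 therefore cannot be read. The compounds shown leave open whether hydrogen in place of methoxycarbonyl changes the toxicity in this test at all.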